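Guanidine side chain to methylsulfanyl on the shared core

This account rests on a few compounds, and the source may have more. Where it says the series, first, only, none or still open, it means among the compounds named here.

Compound 1 `O=C(CN(c1ncnc2c1ncn2C1CCCCO1)C1CC1)N[C@@H](CO)C(=O)OCc1ccccc1` gives 29.2% in a functional assay on the whole organism (Tail, strain ICR) with Mus musculus as the target, in the tail flick test, with a stated time of 120 min, at a dose of 25 umol/kg by the oral route; a lower number here means a weaker effect, a higher number a stronger effect of the compound at the dose given. Compound 2 `N=C(N)NCCC[C@H](NC(=O)CN(c1ncnc2c1ncn2C1CCCCO1)C1CC1)C(=O)OCc1ccccc1` gives 38.2% in this assay. Going by the values given here, the one step between them, a number 9 percentage points higher from compound 1 to compound 2 (within the scatter), leaves the pair unseparated; compound 2 holds the upper of the two numbers, with compound 1 its nearest neighbour inside the scatter.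

Compound 3 `CSCC[C@H](NC(=O)CN(c1ncnc2c1ncn2C1CCCCO1)C1CC1)C(=O)OCc1ccccc1` is not yet measured. Against compound 2 the change is a group of 2 heavy atoms (1 carbon, 1 sulfur; no ring) in place of a group of 5 heavy atoms (2 carbon, 3 nitrogen; no ring), on a saturated chain carbon, three bonds along the chain from an amide-type nitrogen and a carbonyl carbon. Among the compounds with values here, no measured step touches this position: the single step, a number 9 percentage points higher from compound 1 to compound 2 (within the scatter), concerns a different side chain and was itself within the scatter. Within the data shown here, the series so far therefore gives no ground for a move beyond the scatter in either direction.

The step expected is a number 5.2 percentage points lower from compound 2 to compound 3 (within the scatter), judged as no change beyond the scatter. Compound 3 is estimated at 33%, with a range from 15% to 52%.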

Compound 3, a percentage reported as activity, at one dose (the size of the read-out at that dose, not a potency): 28.7%
Compound 3: middle estimate off by 4.3 percentage points, on the high side, and the stated range covers the measured number.
By their numbers in this assay, from the lowest: compounds 3, 1 and 2 (each within the scatter of the next).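

The exchange of the group of 5 heavy atoms, with its hydrogen-bond donors, for methylsulfanyl comes with a number 9.5 percentage points lower from compound 2 to compound 3 (within the scatter) and so does not separate the two compounds in this assay. Setting (methylsulfanyl)methyl in place of hydroxy gives a number 0.5 percentage points lower from compound 1 to compound 3 (within the scatter) and likewise separates nothing, so the three side chains shown, which differ widely in size and in their donors, support no order among themselves. No data at hand bear on why these side chains read alike.

Still open, from the compounds shown here alone, is whether a side chain ending in a carboxylic acid or an amine, or a longer chain, would move the read-out beyond the scatter. Also open, going by these compounds, is whether these compounds would separate at another dose or time.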